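Tetrazole for carboxylic acid on two related pyroglutamide cores

The source may report more compounds than this note shows. Statements on the series, on what has been measured and on what is new or still open speak of the compounds shown alone.

Measured so far:
Compound 1, `O=C(O)c1ccc(COc2ccc(CNC(=O)[C@@H]3CCC(=O)N3Cc3ccc(F)cc3)cc2)cc1`: > 5000 nM in an assay on HEK293 cells for inhibition of Ataxin-2 (Mus musculus), read by fluorescence and Amplex Red; on this read-out higher numbers stand for weaker inhibition and lower numbers for stronger inhibition
Compound 2, `O=C(NCc1ccc(OCc2ccc(-c3nn[nH]n3)cc2)cc1)[C@@H]1CCC(=O)N1Cc1ccc(F)cc1`: > 5000 nM in this assay
Compound 3, `O=C(O)c1ccc(COc2ccc(CN3C(=O)CC[C@H]3C(=O)NCc3ccccc3)cc2)cc1`: > 5000 nM in this assay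

Of the compounds shown here, three have been measured in this assay, and none gives a number. Compound 1 reaches only the limit of the assay, > 5000 nM. Compound 2 likewise stops at the limit, > 5000 nM. Compound 3 also returns the limit alone, > 5000 nM. The step from compound 1 to compound 2 is a step that the two limits leave unreadable from compound 1 to compound 2; its structural change is 2H-tetrazol-5-yl in place of carboxy on an aromatic carbon. Since both ends are limits, the size of that step cannot be read, a point summed up by the limit of > 5000 nM in this assay, at which 3 of the 3 values shown sit.

Compound 4, `O=C(NCc1ccccc1)[C@@H]1CCC(=O)N1Cc1ccc(OCc2ccc(-c3nn[nH]n3)cc2)cc1`, has not yet been measured in this assay. It stands to compound 3 as compound 2 stands to compound 1: the change is 2H-tetrazol-5-yl in place of carboxy on an aromatic carbon. The place where the change happens is described in the same words for both pairs, so it is the same change on a different core; how the core of compound 3 differs from that of compound 1 is not broken down here.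

The expectation for compound 4 rests on what is known of its two neighbours. Compound 3 gives > 5000 nM, and the change from compound 1 to compound 2 left that pair at the same limit. Compound 4 is therefore estimated at 10000 nM, within 5000 nM to 60000 nM, a step that the limit leaves unreadable from compound 3 to compound 4 that is expected to leave the assay reporting a limit rather than a number.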

Compound 4, half-maximal inhibitory concentration: > 5000 nM
Compound 4: no number, only a limit (the forecaster's own chance of this, stated with the estimate: 90%); the middle value is on the limit's open side.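

In this assay compound 4 gives > 5000 nM, which is a limit and not a number. Compound 3 also stands at a limit, so no size can be read for the change from compound 3 to compound 4. The compounds shown leave open how strongly any of them inhibits and whether 2H-tetrazol-5-yl and carboxy differ on either core, with one limit shared by all: the limit of > 5000 nM in this assay, at which 4 of the 4 values shown sit.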